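Adding a Second Chlorine to the Aryl Ether of Compound 2

This account rests on a few compounds, and the source may have more. Where it says the series, first, only, none or still open, it means among the compounds named here.

Compound 1 `Cc1ccc(OCCCON2C(N)=NC(N)=NC23CCOCC3)cc1` — 2390 nM
Compound 2 `NC1=NC2(CCOCC2)N(OCCCOc2ccccc2Cl)C(N)=N1` — 70 nM

Going by the values given here, in a functional assay on HCT-116 cells (Homo sapiens) for antiproliferative activity, read by MTT assay, with a stated time of 72 h (a lower number here means a stronger inhibitor, a higher number a weaker inhibitor), compound 2 gives 70 nM, the lowest of the two numbers measured so far. Compound 1 gives 2390 nM, and the step of a 34-fold lower number from compound 1 to compound 2 (1.53 log units; beyond the scatter) lies beyond the scatter. Compound 3 `NC1=NC2(CCOCC2)N(OCCCOc2ccc(Cl)cc2Cl)C(N)=N1` differs from compound 2 by chloro in place of hydrogen on an aromatic carbon, so that 2-chlorophenyl becomes 2,4-dichlorophenyl. Among the compounds with values here, the only measured step, a 34-fold lower number from compound 1 to compound 2 (1.53 log units; beyond the scatter), exchanged one whole aryl group for another and does not test what a further chloro group does to an aryl group that already gave the lower number; no step in the data bears on this change directly. Compound 3 is therefore expected to stay close to compound 2, at an estimated 60 nM with a range of 20 nM to 180 nM. The expected step is a 1.2-fold lower number from compound 2 to compound 3 (0.07 log units; within the scatter), not beyond the scatter.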

Compound 3, half-maximal inhibitory concentration: 880 nM
Compound 3: the middle estimate sits 15-fold (1.17 log units) below what was measured, and the stated range ends below it.
By their numbers in this assay, from the lowest: compound 2; then compound 3; then compound 1.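

In this assay, the new chloro group, para to a large group and meta to the chloro group already present, is far from a neutral addition: it gives a 13-fold higher number from compound 2 to compound 3 (1.10 log units; beyond the scatter) and so takes back much of the gain that 2-chlorophenyl brought. The 2,4-dichlorophenyl group still keeps a smaller edge over 4-methylphenyl, with a 2.7-fold lower number from compound 1 to compound 3 (0.43 log units; beyond the scatter) on the same core, so the lower number of compound 2 depends on what occupies this one place on the aryl group. Nothing at hand explains this loss.

The compounds shown leave open whether fluoro, methoxy or an amine at this place would raise the number as chloro does. They also leave open how 4-chlorophenyl, without the second chloro group, would read.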